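The compounds below may be only part of what the source reports. "The series", "measured", "known", "first", "only" and "open" are said of these compounds alone.

Working notes on the carboxylic-acid ring series. All three measured compounds share one core and differ only in the saturated acid-bearing ring on the aromatic carbon. Compound 1 `CCNC(=O)Nc1nc2cc(-c3cnc(N4CCC(C(=O)O)CC4)nc3)cc(-c3ccccn3)c2s1` carries 4-carboxypiperidin-1-yl; in a physicochemical assay for solubility, read by turbidimetry, in phosphate buffer, with a stated time of 24 h, at pH 7.4 (a higher number here means a more soluble compound, a lower number a less soluble compound), compound 1 gives > 800 ug/mL, which is a limit of the assay and not a number. Compound 2 `CCNC(=O)Nc1nc2cc(-c3cnc(N4CCC(C)(C(=O)O)C4)nc3)cc(-c3ccccn3)c2s1` carries 3-carboxy-3-methylpyrrolidin-1-yl, and in this assay compound 2 gives > 800 ug/mL, again a limit. Among the measured compounds shown here, compound 3 `CCNC(=O)Nc1nc2cc(-c3cnc(N4CCCCC4(C)C(=O)O)nc3)cc(-c3ccccn3)c2s1` carries 2-carboxy-2-methylpiperidin-1-yl, and in this assay compound 3 gives 6.25 ug/mL, the only actual number in the set; the two other values sit at the limit of > 800 ug/mL in this assay, at which 2 of the 3 values shown sit. The step that the two limits leave unreadable from compound 1 to compound 2 cannot be read from two limits. The steps of an at least 120-fold lower number from compound 1 to compound 3 (2.10 log units; beyond the scatter) and an at least 120-fold lower number from compound 2 to compound 3 (2.10 log units; beyond the scatter) are both large, so compound 3 stands far below the rest of the set. Compound 4 `CCNC(=O)Nc1nc2cc(-c3cnc(N4CCCC(C)(C(=O)O)CC4)nc3)cc(-c3ccccn3)c2s1` differs from compound 3 by 4-carboxy-4-methylazepan-1-yl in place of 2-carboxy-2-methylpiperidin-1-yl on an aromatic carbon. The change removes the 2-carboxy-2-methylpiperidin-1-yl group that alone accompanies the low value and brings in a carboxy-methyl ring of the kind carried by compound 1 and compound 2. Compound 4 is therefore expected to regain much of the solubility, an estimated step of a 64-fold higher number from compound 3 to compound 4 (1.81 log units; beyond the scatter). The estimate for compound 4 is 400 ug/mL, with a range from 50 ug/mL to 800 ug/mL.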

Compound 4, solubility: > 800 ug/mL
Compound 4: only a limit was reported; the forecaster's own chance of this, stated with the estimate: 45%; at least 2.0-fold (0.30 log units) between middle value and limit.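

In this assay, the change at this aromatic carbon, between two ring nitrogen atoms, from 2-carboxy-2-methylpiperidin-1-yl to 4-carboxy-4-methylazepan-1-yl gives an at least 120-fold higher number from compound 3 to compound 4 (2.10 log units; beyond the scatter), so a seven-membered ring carrying both methyl and carboxy on one carbon is now seen to be compatible with the high end of the range. Neither the carboxy-and-methyl pairing on one ring carbon nor the donor and acceptor counts, which are the same for the leaving and entering groups, separate compound 3 from compound 4, and among the four compounds only compound 3 gives a low value. The steps to compound 4 from compound 1 and from compound 2 join two limits and cannot be read, and the series now gathers at one end of this assay: the limit of > 800 ug/mL in this assay, at which 3 of the 4 values shown sit.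

The compounds shown leave open whether the low value of compound 3 goes with the methyl group or with the carboxy group's place on the ring, a question that 2-carboxypiperidin-1-yl would address. Also open, on these data alone, are the order among compound 1, compound 2 and compound 4, and the outcome at this position for a ring bearing an amine instead of the carboxylic acid.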